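A Methyl Removed at the Ether of Compound 1

The compounds below may be only part of what the source reports. "The series", "measured", "known", "first", "only" and "open" are said of these compounds alone.

Three compounds were tested in an assay for inhibition of solute carrier family 22 member 12 (Homo sapiens), read by scintillation counting, with a stated time of 60 min, tested at 50 uM; on this read-out lower numbers stand for less inhibition and higher numbers for more inhibition at the one concentration tested (going by the name of the read-out). Compound 1, `CCc1oc2ccc(OC)cc2c1C(=O)c1ccc(OC)cc1`, gives 24.3%, the highest of the three. Compound 2, `CCc1cc2cc(OC)cc(C(=O)c3ccc(OC)cc3)c2o1`, gives 5.2%, and compound 3, `CCc1cc2c(C(=O)c3ccc(OC)cc3)ccc(OC)c2o1`, gives 7.4%; both lie beyond the scatter below compound 1. Among the measured compounds shown here, no pair of these differs in only one place, so no single step between measured compounds can be told. Compound 4, `CCc1oc2ccc(OC)cc2c1C(=O)c1ccc(O)cc1`, is not yet measured. It differs from compound 1 by hydrogen in place of methyl on an oxygen on an aromatic ring. For the measured compounds named here, with no comparable step among the measured compounds, only a small step in this assay is expected, in either direction or none beyond the scatter, estimated as a number 3.7 percentage points higher from compound 1 to compound 4 (within the scatter). Compound 4 is therefore expected to give about 28%, within a range from 10% to 50%.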

Compound 4, a percentage reported as inhibition, at one concentration (the size of the read-out at that concentration, not a potency): 92.7%
For compound 4 the middle estimate is 64.7 percentage points below the measured one; the whole stated range lies below it.
By their numbers in this assay, from the lowest: compounds 2 and 3 (each within the scatter of the next); then compound 1; then compound 4.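

Among the compounds shown here, the methyl on this oxygen carries far more weight than the earlier compounds could show: in this assay, going from methoxy to hydroxy at this one place gives a number 68.4 percentage points higher from compound 1 to compound 4 (beyond the scatter). For the compounds shown here, compounds 1, 2 and 3 offered no single change to read, so this is the first step that ties the read-out to one place, and it is large. Nothing shown accounts for the size of this step.

From the compounds shown here alone, what an amine or a carboxylic acid would give in this place remains open, as does an ethyl on the same oxygen. Also open, going by these compounds, is whether the same methoxy to hydroxy change at the other methoxy of compound 1 would give a step of similar size.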